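A few compounds are considered here, and "the series" means these few. Any claim that something is new, unique, unknown or untested is made for them only; others in the source may bear on it.

Of the compounds shown here, two have so far been measured in an assay on isolated protein for inhibition of DNA topoisomerase 1 (Homo sapiens), with a stated time of 30 min, tested at 20 uM; a higher number here means a stronger effect of the compound at the concentration tested, a lower number a weaker effect. Compound 1 `Oc1ccc(-c2cc(-c3cccs3)cc(-c3cccc(O)c3)n2)cc1` gives 1.1% in this assay. Compound 2 `Oc1cccc(-c2cc(-c3ccco3)cc(-c3cccc(O)c3)n2)c1` gives 0% in this assay, a number that lies within the scatter of the number for compound 1. Compound 3 `Oc1ccc(-c2cc(-c3ccco3)cc(-c3cccc(O)c3)n2)cc1` is not yet measured; it differs from compound 2 by 4-hydroxyphenyl in place of 3-hydroxyphenyl on an aromatic carbon. For the measured compounds named here, no measured pair shows this change, so no direction can be drawn from the series. Both measured numbers sit near zero, and a step of a number 1 percentage points higher from compound 2 to compound 3 (within the scatter) is expected, not beyond the scatter. Compound 3 is expected to give 1% in this assay, with a range from 0% to 8%.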

Compound 3, a percentage reported as inhibition, at one concentration (the size of the read-out at that concentration, not a potency): 1.5%
Compound 3: middle estimate off by 0.5 percentage points, on the low side; the range from low to high includes it.
By their numbers in this assay, from the lowest: compounds 2, 1 and 3 (each within the scatter of the next).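

In this assay, 4-hydroxyphenyl in place of 3-hydroxyphenyl next to the ring nitrogen gives a number 1.5 percentage points higher from compound 2 to compound 3 (within the scatter), and furan-2-yl in place of thiophen-2-yl gives a number 0.4 percentage points higher from compound 1 to compound 3 (within the scatter), so neither single change lifts the read-out clear of the scatter around zero. No supporting data bear on these results.

Open, going by these compounds, is whether any substituent on the core of compound 3 gives a clear read-out at this concentration. An amine or a carboxylic acid in place of either hydroxyl group, or a methoxy group on either phenyl ring, would test this.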